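The source may hold more compounds than are shown below. What is called first, only, known or untested is meant among the compounds shown, and "the series" means these compounds.

Three chalcone-type compounds share one core and differ only in the aryl group on the carbonyl carbon. In a functional assay on B16-F10 cells (Mus musculus) for antiproliferative activity, read by MTT assay, with a stated time of 48 h (on this read-out higher numbers stand for weaker inhibition and lower numbers for stronger inhibition), compound 1 `COc1ccc(/C=C/c2cc(OC)cc(OC)c2/C=C/C(=O)c2ccc(Cl)c(Cl)c2)cc1` gives 7.5 ug/mL, compound 2 `COc1ccc(/C=C/c2cc(OC)cc(OC)c2/C=C/C(=O)c2cccc(Cl)c2)cc1` gives 3.3 ug/mL, and compound 3 `COc1ccc(/C=C/c2cc(OC)cc(OC)c2/C=C/C(=O)c2ccc(F)cc2)cc1` gives 5.3 ug/mL. Compound 2 has the lowest of these three numbers, though its gap to compound 3 lies within the scatter a 1.6-fold higher number from compound 2 to compound 3 (0.21 log units; within the scatter), while its gap to compound 1 lies beyond it a 2.3-fold lower number from compound 1 to compound 2 (0.36 log units; beyond the scatter). Compound 4 `CCN(CC)c1ccc(C(=O)/C=C/c2c(/C=C/c3ccc(OC)cc3)cc(OC)cc2OC)cc1` differs from compound 2 as follows: 4-(diethylamino)phenyl in place of 3-chlorophenyl on a carbonyl carbon. The swaps on the carbonyl carbon seen so far were small, as in a 1.4-fold lower number from compound 1 to compound 3 (0.15 log units; within the scatter), yet none introduced a diethylamino group, so the data bear only loosely. Compound 4 is therefore expected to show a modest shift a 1.5-fold higher number from compound 2 to compound 4 (0.18 log units; within the scatter), with an estimated 5 ug/mL between 1.5 ug/mL and 16 ug/mL.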

Compound 4, half-maximal inhibitory concentration: 8.1 ug/mL
For compound 4 the middle estimate is 1.6-fold (0.21 log units) below the measured one; low and high end bracket the measured number.
By their numbers in this assay, from the lowest: compounds 2, 3, 1 and 4 (each within the scatter of the next, the first and the last beyond it).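

On the carbonyl carbon, in this assay, 4-(diethylamino)phenyl brings in the first nitrogen at this position, and its step from 3-chlorophenyl lies beyond the scatter (a 2.5-fold higher number from compound 2 to compound 4 (0.39 log units; beyond the scatter)). The steps from the other two aryl groups stay within the scatter (a 1.5-fold higher number from compound 3 to compound 4 (0.18 log units; within the scatter); a 1.1-fold higher number from compound 1 to compound 4 (0.03 log units; within the scatter)), so this change sets compound 4 apart only from compound 2. Nothing available gives a reason for this step. Open, on these data alone, is whether dimethylamino or a carboxylic acid on the same aromatic carbon would give a number like that of compound 4.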